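This account rests on a few compounds, and the source may have more. Where it says the series, first, only, none or still open, it means among the compounds named here.

The two measured compounds share a single core and differ only at one aromatic carbon. Compound 1 `C[C@@H]1CN(c2scnc2-c2nc3ccccc3[nH]2)CCN1C(=O)Cn1cnc2cccnc21` gives 830 nM in a functional assay on U2OS cells for antagonist activity at C-X-C chemokine receptor type 3 (Homo sapiens), read by beta-arrestin recruitment; on this read-out lower numbers stand for stronger inhibition and higher numbers for weaker inhibition. Compound 2 `C[C@@H]1CN(c2sc(Br)nc2-c2nc3ccccc3[nH]2)CCN1C(=O)Cn1cnc2cccnc21` gives 126 nM in this assay. Among the compounds with values here, the one recorded step, a 6.6-fold lower number from compound 1 to compound 2 (0.82 log units; beyond the scatter), is therefore the whole of what is known so far, and compound 2 stands at the lower of the two numbers.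

Compound 3 `C[C@@H]1CN(c2sc(C(F)(F)F)nc2-c2nc3ccccc3[nH]2)CCN1C(=O)Cn1cnc2cccnc21` is the next member of the series. It differs from compound 2 by trifluoromethyl in place of bromo on an aromatic carbon. Within the data shown here, no measured pair exchanges bromo for another group, so the only step that bears on this change is the one from hydrogen to bromo on the same carbon, a 6.6-fold lower number from compound 1 to compound 2 (0.82 log units; beyond the scatter). That step shows that a group placed on this carbon went with a lower number, but it does not tell how one such group compares with another. Compound 3 is consequently expected to land near compound 2, with the step of a 1.2-fold higher number from compound 2 to compound 3 (0.08 log units; within the scatter) in this assay staying within the usual scatter. The estimate for compound 3 in this assay is 150 nM, with a range from 60 nM to 400 nM.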

Compound 3, half-maximal inhibitory concentration: 31 nM
Beside the measured number, compound 3's estimate is 4.8-fold (0.68 log units) above it, and the stated range ends above it.
By their numbers in this assay, from the lowest: compound 3; then compound 2; then compound 1.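

In this assay this carbon, next to the ring nitrogen and next to the ring sulfur, separates one substituent from another and not only a substituent from hydrogen: trifluoromethyl in place of bromo gives a 4.1-fold lower number from compound 2 to compound 3 (0.61 log units; beyond the scatter), a step beyond the scatter. Trifluoromethyl in place of hydrogen gives a 27-fold lower number from compound 1 to compound 3 (1.43 log units; beyond the scatter), a large step that goes well past the modest one for bromo in place of hydrogen, a 6.6-fold lower number from compound 1 to compound 2 (0.82 log units; beyond the scatter), so the identity of the group on this carbon matters as well as its presence. Neither bromo nor trifluoromethyl carries a hydrogen-bond donor or acceptor, so the step comes with no change in those counts, and no measurement at hand accounts for it.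

Going by these compounds, how a nitrile, an amine or a longer chain such as ethyl on this carbon would compare with trifluoromethyl remains open. On these data alone, all three compounds also carry the same core elsewhere, and whether the step from bromo to trifluoromethyl would hold with a different group on the piperazine-side amide or on the other rings also stays unknown.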